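Aryl group change on a thiazolyl acetic acid antagonist

The compounds below may be only part of what the source reports. "The series", "measured", "known", "first", "only" and "open" are said of these compounds alone.

Measured compounds:
compound 1, `O=C(O)Cc1sc(C(Cc2ccccc2)c2ccccc2)nc1-c1ccc(Cl)cc1`, 510 nM
compound 2, `O=C(O)Cc1sc(C(c2ccccc2)c2ccccc2)nc1-c1cccc(F)c1`, 29 nM

Of the compounds shown here, two have been measured in an in vitro functional assay on HEK285-7 cells for antagonist activity at prostaglandin D2 receptor 2 (Homo sapiens), read by BRET and beta-arrestin recruitment; a higher number here means a weaker inhibitor, a lower number a stronger inhibitor. Compound 1 gives 510 nM in this assay. Compound 2 gives 29 nM, the lower of the two numbers; its nearest neighbour is compound 1, whose number is higher by a gap that lies beyond the scatter. For the measured compounds named here, the two measured compounds differ in more than one place, so no single step between them is known, and the two values can only be read side by side.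

Compound 3, `COc1ccc(OC)c(-c2nc(C(c3ccccc3)c3ccccc3)sc2CC(=O)O)c1`, has not yet been measured in this assay. It differs from compound 2 in one place: 2,5-dimethoxyphenyl in place of 3-fluorophenyl on an aromatic carbon. Going by the values given here, no measured pair isolates such a change at this position, so the direction of the step rests on the structural change alone. A modest loss of potency is expected, with the step of a 2.8-fold higher number from compound 2 to compound 3 (0.44 log units; beyond the scatter) estimated to fall at the edge of the scatter. For compound 3 a value of 80 nM is expected in this assay, within a range from 20 nM to 400 nM.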

Compound 3, half-maximal inhibitory concentration: > 100000 nM
Compound 3 was reported as a limit; the forecaster's own chance of this, stated with the estimate: 5%; middle value at least 1200-fold (3.09 log units) from the limit.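

In this assay compound 3 gives > 100000 nM, a limit of the assay and not a number. For the compounds shown here, on this aromatic carbon, next to the ring nitrogen and next to the ring atom that bears the carboxymethyl group, the exchange of 3-fluorophenyl for 2,5-dimethoxyphenyl is the first single change that can be read, and it gives an at least 3400-fold higher number from compound 2 to compound 3 (3.53 log units; beyond the scatter), so the aryl group at this position can decide between a clear reading and none within the range of the assay, whereas the two earlier compounds, which differ in more than one place, could only be set side by side. The true size of this step remains unknown, because it rests on a limit: the limit of > 100000 nM in this assay, at which 1 of the 3 values shown sits.

The compounds shown leave open whether the loss comes from one of the two methoxy groups alone or needs both of them, since no phenyl group carrying a single methoxy group stands among them. They also leave open how a hydroxyl group or an amine on this aryl ring would read in this assay.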